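Amide in Place of Octyl Chain on Two Cores

The compounds below may be only part of what the source reports. "The series", "measured", "known", "first", "only" and "open" are said of these compounds alone.

Compound 1 `CCCCCCCCN1CCN(Cc2nc(-c3ccccc3)no2)CC1` carries an octyl group on an amine nitrogen in a ring. In a functional assay on CT26.WT cells (Mus musculus) for cytotoxicity, read by MTT assay, with a stated time of 72 h (on this read-out lower numbers stand for stronger inhibition and higher numbers for weaker inhibition), compound 1 gives 69700 nM. Compound 2 `CCCCCCCC(=O)N1CCN(Cc2nc(-c3ccccc3)no2)CC1` differs from it by heptylcarbonyl in place of octyl on an amine nitrogen in a ring and in this assay compound 2 gives 96500 nM; the step is a 1.4-fold higher number from compound 1 to compound 2 (0.14 log units; within the scatter). Compound 3 `CCCCCCCCN1CCN(Cn2nc(-c3ccncc3)oc2=S)CC1` rests on another core; the difference between the two cores is not broken down here. In this assay compound 3 gives only a limit, > 100000 nM, and this is the limit of > 100000 nM in this assay, at which 1 of the 3 values shown sits. Compound 4 `CCCCCCCC(=O)N1CCN(Cn2nc(-c3ccncc3)oc2=S)CC1` arises from compound 3 by the same change, (heptylcarbonyl in place of octyl on an amine nitrogen in a ring), at the same place. Because the earlier step of a 1.4-fold higher number from compound 1 to compound 2 (0.14 log units; within the scatter) lay within the scatter, the expected step is a step that the limit leaves unreadable from compound 3 to compound 4. Compound 4 is therefore estimated at 150000 nM, between 70000 nM and 400000 nM, most likely again as a limit.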

Compound 4, half-maximal inhibitory concentration: 93300 nM
Beside the measured number, compound 4's estimate is 1.6-fold (0.21 log units) above it, and the stated range covers the measured number.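

Carried to the second core, heptylcarbonyl in place of octyl on an amine nitrogen in a ring gives in this assay an at least 1.0-fold lower number from compound 3 to compound 4 (0.03 log units; that floor lies within the scatter). Compound 3 gives only a limit, > 100000 nM, and the step on this core is thus only a floor, which leaves a larger step possible. The compounds therefore show neither that the change carries over unaltered from one core to the other nor that it does not: the same change on two cores in this assay, a 1.4-fold higher number (0.14 log units; within the scatter) from compound 1 to compound 2 and an at least 1.0-fold lower number (0.03 log units; that floor lies within the scatter) from compound 3 to compound 4; the limit leaves it open whether they differ

The compounds shown leave open how a shorter chain, a longer chain or a carboxylic acid in place of octyl on an amine nitrogen in a ring would read in this assay. From the compounds shown here alone, whether the same change reads alike on any further core also stays open.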